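Swapping Chloro for Methoxy on a Shared Amide Core

This account rests on a few compounds, and the source may have more. Where it says the series, first, only, none or still open, it means among the compounds named here.

Measured so far:
Compound 1, `COc1cc(NC(=O)c2cnc(C)cn2)c2ncccc2c1`, gives 6700 nM.
Compound 2, `O=C(Nc1cc(F)cc2cccnc12)c1cnccn1`, gives only a limit of the assay, > 10000 nM.
Compound 3, `O=C(Nc1cc(Cl)cc2cccnc12)c1cnccn1`, gives only a limit of the assay, > 10000 nM.

All three were tested in a functional assay on BXPC-3 cells (Homo sapiens) for inhibition, read by MTT assay, with a stated time of 72 h; a higher number here means a weaker inhibitor, a lower number a stronger inhibitor. Compound 1 is the only one of the three with a readable number. Compound 3 stands at a limit, not a number, and the limit of > 10000 nM in this assay, at which 2 of the 3 values shown sit, marks where it sits. Among the compounds with values here, the single measured step, a step that the two limits leave unreadable from compound 2 to compound 3, is therefore unreadable, since both ends are limits.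

Compound 4, `COc1cc(NC(=O)c2cnccn2)c2ncccc2c1`, differs from compound 3 by methoxy in place of chloro on an aromatic carbon. Within the data shown here, no measured step involves this exchange, so none bears on it directly. Among the measured compounds shown here, the only hint is that compound 1, which also carries the methoxy, gives a number rather than a limit, whereas compound 3 does not.

Compound 4 is therefore expected near 8000 nM, within a range from 3000 nM to 20000 nM. The corresponding step, an at least 1.2-fold lower number from compound 3 to compound 4 (0.09 log units; that floor lies within the scatter), is an estimate only, and the limit of this assay may again be reported.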

Compound 4, half-maximal inhibitory concentration: 470 nM
Compound 4: the middle estimate sits 17-fold (1.23 log units) above what was measured; the measured number lies below the stated range.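

Methoxy in place of chloro brings an at least 21-fold lower number from compound 3 to compound 4 (1.32 log units; beyond the scatter), and methoxy in place of fluoro brings an at least 21-fold lower number from compound 2 to compound 4 (1.32 log units; beyond the scatter), so in this assay the result at this aromatic carbon, para to a fused ring, depends strongly on the group it carries. These sizes are only floors, because compound 2 and compound 3 each stop at a limit of the assay: the limit of > 10000 nM in this assay, at which 2 of the 4 values shown sit. With the methoxy kept in place, hydrogen in place of methyl on an aromatic carbon gives a 14-fold lower number from compound 1 to compound 4 (1.15 log units; beyond the scatter), so the methoxy alone does not set the level of activity.

The step between the two halogen compounds cannot be read, which leaves fluoro and chloro unranked. From the compounds shown here alone, it also remains open whether a hydroxy group, an ethoxy group or an amine on this carbon would match methoxy or do better.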